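Methyl Added to Compound 3 Bearing Chloro

The source may hold more compounds than are shown below. What is called first, only, known or untested is meant among the compounds shown, and "the series" means these compounds.

Compound 3 `CC1=NN(c2ccc(Cl)cc2)C(=O)C12C=CC(=O)C=C2c1ccccc1` sits at a limit: in a functional assay on HCT-116 cells (Homo sapiens) for antiproliferative activity, read by CCK-8 assay, with a stated time of 72 h (a lower number here means a stronger inhibitor, a higher number a weaker inhibitor), compound 3 reaches only > 100000 nM, which is a limit of the assay rather than a number. Its parent, compound 2 `CC1=NN(c2ccccc2)C(=O)C12C=CC(=O)C=C2c1ccccc1`, gives 17800 nM in this assay, and the step from compound 2 to compound 3 an at least 5.6-fold higher number from compound 2 to compound 3 (0.74 log units; beyond the scatter) placed chloro on an aromatic carbon, with the limit of > 100000 nM in this assay, at which 1 of the 3 values shown sits, bounding how much could be seen. Compound 1 `CC1=NN(c2ccc(C)cc2)C(=O)C12C=CC(=O)C=C2c1ccc(C)cc1` differs from compound 2 in more than one place; in this assay compound 1 gives 9710 nM, so the two values stand close together.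

Compound 4 `CC1=NN(c2ccc(Cl)cc2)C(=O)C12C=CC(=O)C=C2c1ccc(C)cc1` takes compound 3 and makes the change (methyl in place of hydrogen on an aromatic carbon), para to a large group, on the six-membered aromatic ring of carbon only. Among the measured compounds shown here, no measured step isolates this single methyl, and the pair compound 1 and compound 2 shows only a small gap. Compound 3 already sits at the limit, so the step from compound 3 to compound 4 is expected to be a number no higher from compound 3 to compound 4 (the limit leaves the size open), with compound 4 expected near 100000 nM in this assay, between 40000 nM and 300000 nM, and likely again reported only as a limit.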

Compound 4, half-maximal inhibitory concentration: 10300 nM
The estimate for compound 4 lay 9.7-fold (0.99 log units) above the measured number; the whole stated range lies above it.
By their numbers in this assay, from the lowest: compounds 1, 4 and 2 (each within the scatter of the next). At a limit, above all of these: compound 3.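

In this assay, phenyl to 4-methylphenyl on the six-membered aromatic ring of carbon only, para to a large group, gives an at least 9.7-fold lower number from compound 3 to compound 4 (0.98 log units; beyond the scatter), the first single step shown for methyl at this position. With this methyl present, the chloro group no longer goes with a value at the limit: chloro in place of methyl on the other aromatic ring gives a 1.1-fold higher number from compound 1 to compound 4 (0.03 log units; within the scatter), so the two groups are not told apart there. Compound 3 stands at a limit rather than a number, which leaves the full size of the methyl step open: the limit of > 100000 nM in this assay, at which 1 of the 4 values shown sits.

The compounds shown leave open whether this methyl would bring a similar step without the chloro group. They also leave open how an amine, a carboxylic acid or a longer chain would read at this position.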